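A Methyl Added to an Inactive Benzyl Ether

A few compounds are considered here, and "the series" means these few. Any claim that something is new, unique, unknown or untested is made for them only; others in the source may bear on it.

Three compounds have been measured in a functional assay on KB cells (Homo sapiens) for antiproliferative activity, read by sulforhodamine B assay, with a stated time of 72 h; a lower number here means a stronger inhibitor of growth, a higher number a weaker inhibitor of growth:

Compound 1 `Cc1cc(=O)oc2cc(SCc3ccccn3)ccc12` reaches only the limit > 35200 nM in this assay.
Compound 2 `CCc1cc(=O)c2ccc(Sc3cccc(Cl)n3)c(C)c2o1` reaches only the limit > 30100 nM in this assay.
Compound 3 `CCc1cc(=O)c2ccc(OCc3ccccc3)c(C)c2o1` reaches only the limit > 33900 nM in this assay.

None of the three values is a real number; each is a limit of the assay. Compound 3 therefore cannot be placed above or below its neighbours: it sits at a limit, as do the other two, and the three limits (the limit of > 30100 nM in this assay, at which 1 of the 3 values shown sits), the limit of > 33900 nM in this assay, at which 1 of the 3 values shown sits, and the limit of > 35200 nM in this assay, at which 1 of the 3 values shown sits, are all that the data show. For the measured compounds named here, no step between two measured compounds exists here.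

Compound 4 `CCc1cc(=O)c2ccc(OCc3cccc(C)c3)c(C)c2o1` is the next one to test. It differs from compound 3 in a single way: methyl in place of hydrogen on an aromatic carbon. Going by the values given here, no measured step shows what a small change of this kind does on this scaffold, so there is no ground to expect a shift beyond the scatter in this assay. Compound 4 is estimated to behave like compound 3, and the expected step is a step that the limit leaves unreadable from compound 3 to compound 4. For compound 4 the estimated value in this assay is 40000 nM, with a likely range from 12000 nM to 120000 nM, and most probably the assay will again report only a limit.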

Compound 4, concentration for 50% growth inhibition: 28600 nM
For compound 4 the middle estimate is 1.4-fold (0.15 log units) above the measured one; low and high end bracket the measured number.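

For the compounds shown here, on the benzyl ether of compound 3, methyl in place of hydrogen on an aromatic carbon, the change from phenyl to 3-methylphenyl, gives the first reading in this assay that is a real number and not a limit, with compound 4 at 28600 nM. The step reads an at least 1.1-fold lower number from compound 3 to compound 4 (0.07 log units; that floor lies within the scatter), so this small change cannot be said to strengthen growth inhibition, although the true step may be larger than this floor. The step can be given only as a floor because compound 3 itself stands at a limit of the assay: the limit of > 33900 nM in this assay, at which 1 of the 4 values shown sits.

A single methyl at a single place on this ring says nothing yet about whether the number would keep falling with a different group there, such as a longer chain like propyl, an amine or a carboxylic acid. It also leaves open whether the same methyl on another carbon of that ring would give a number at all, or whether the assay would again report only a limit.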